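A few compounds are considered here, and "the series" means these few. Any claim that something is new, unique, unknown or untested is made for them only; others in the source may bear on it.

Measured so far: compound 1 `Oc1cccc(-c2cc(-c3ccc(Cl)cc3)nc(-c3cccnc3)c2)c1`, 26800 nM; compound 2 `Oc1cccc(-c2cc(-c3cccc(Cl)c3)nc(-c3ccco3)c2)c1`, 2020 nM; compound 3 `Oc1cccc(-c2cc(-c3ccc(Cl)cc3)nc(-c3ccccn3)c2)c1`, 8090 nM, all in a functional assay on DU-145 cells (Homo sapiens) for cytotoxicity, read by CCK-8 assay and cell counting, with a stated time of 2 days; a lower number here means a stronger inhibitor, a higher number a weaker inhibitor.

Compound 3 stands second highest of the three numbers in this assay; its nearest neighbour is compound 1, which sits higher by a 3.3-fold lower number from compound 1 to compound 3 (0.52 log units; beyond the scatter), and compound 2 lies furthest from it, with a lower number.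

Compound 4 `Oc1cccc(-c2cc(-c3ccc(Cl)cc3)nc(-c3ccco3)c2)c1` is not yet measured. It differs from compound 3 in one place: furan-2-yl in place of pyridin-2-yl on an aromatic carbon. Within the data shown here, no measured step covers this exact change. Among the measured compounds shown here, the one step on record, a 3.3-fold lower number from compound 1 to compound 3 (0.52 log units; beyond the scatter), concerns a change between two pyridinyl isomers at the same place and is modest. For the measured compounds named here, compound 2 carries the furan-2-yl group but also a 3-chlorophenyl group, so it differs from compound 4 in two places; its value and that of compound 3 show only that the furan-bearing compound gave the lower number of the two.

Compound 4 is therefore expected to move somewhat toward the lower side, by about a 2.3-fold lower number from compound 3 to compound 4 (0.36 log units; beyond the scatter), though the uncertainty is wide. The estimate for compound 4 in this assay is 3500 nM, within 1200 nM to 10000 nM.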

Compound 4, half-maximal inhibitory concentration: 11400 nM
Compound 4: the middle estimate sits 3.3-fold (0.51 log units) below what was measured; the measured number lies above the stated range.
By their numbers in this assay, from the lowest: compound 2; then compounds 3 and 4 (each within the scatter of the next); then compound 1.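

In this assay, the change at the aromatic carbon next to the ring nitrogen gives a 1.4-fold higher number from compound 3 to compound 4 (0.15 log units; within the scatter), so furan-2-yl and pyridin-2-yl are not told apart at this place, while a 2.4-fold lower number from compound 1 to compound 4 (0.37 log units; beyond the scatter) puts furan-2-yl, like pyridin-2-yl in a 3.3-fold lower number from compound 1 to compound 3 (0.52 log units; beyond the scatter), on the lower side of pyridin-3-yl. With furan-2-yl held, a step beyond the scatter appears at the other aryl group, a 5.6-fold higher number from compound 2 to compound 4 (0.75 log units; beyond the scatter), so the low number of compound 2 goes with its 3-chlorophenyl group rather than with furan-2-yl. Nothing measured here bears on the reason for these steps.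

Still open, going by these compounds, is whether 3-chlorophenyl gives a similar step with pyridin-2-yl or pyridin-3-yl at the same place. Also open, on these data alone, is whether a non-aromatic group at this place, such as an amine or a carboxylic acid, would separate from furan-2-yl and pyridin-2-yl.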